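The source may hold more compounds than are shown below. What is called first, only, known or untested is meant among the compounds shown, and "the series" means these compounds.

Measured compounds:

Compound 1, `COc1ccc(CN(Cc2ccc(C(C)(C)C)cc2)Cc2cc3cc(C)ccc3[nH]c2=O)cc1`, in a toxicity assay on MDCK cells (Canis lupus familiaris) for cytotoxicity, read by crystal violet staining, with a stated time of 48 h (on this read-out lower numbers stand for higher toxicity in this test and higher numbers for lower toxicity in this test), gives > 10000 nM.

Compound 2, `Cc1ccc2[nH]c(=O)c(CN(Cc3ccc(N(C)C)cc3)Cc3ccc(C(C)(C)C)cc3)cc2c1`, in this assay gives > 5000 nM.

Compound 3, `COc1ccc(C(C)N(Cc2ccc(C(C)(C)C)cc2)Cc2cc3cc(C4CC4)ccc3[nH]c2=O)cc1Cl`, in this assay gives > 10000 nM.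

The value of compound 1 is a limit of the assay and not a number. The value of compound 2 is likewise a limit. The value of compound 3 is a limit as well. Compound 2 differs from compound 1 by dimethylamino in place of methoxy on an aromatic carbon, and the step this change made, a step that the two limits leave unreadable from compound 1 to compound 2, cannot be read, since the two values involved are the limit of > 10000 nM in this assay, at which 2 of the 3 values shown sit, and (the limit of > 5000 nM in this assay, at which 1 of the 3 values shown sits). How the core of compound 3 differs from the core of compound 1 is not broken down here.

Compound 4, `CC(c1ccc(N(C)C)c(Cl)c1)N(Cc1ccc(C(C)(C)C)cc1)Cc1cc2cc(C3CC3)ccc2[nH]c1=O`, has not yet been measured in this assay. It differs from compound 3 by dimethylamino in place of methoxy on an aromatic carbon. This is the same kind of change as that from compound 1 to compound 2, but the surroundings of the place are not identical: in compound 4 the aromatic carbon carrying the new group is ortho to a chloro group (1 heavy atom) and para to a large group, whereas in compound 2 it is only para to a large group.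

With the earlier step unreadable and compound 3 sitting at a limit, the step from compound 3 to compound 4, a number no higher from compound 3 to compound 4 (the limit leaves the size open), is expected to be small. Compound 4 is therefore estimated at 10000 nM in this assay. Compound 4 is expected to fall between 3000 nM and 30000 nM, most likely again reported only as a limit.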

Compound 4, half-maximal cytotoxic concentration: > 10000 nM
Compound 4 was reported as a limit; the forecaster's own chance of this, stated with the estimate: 85%; the middle value sits exactly at the limit.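

In this assay compound 4 gives > 10000 nM, which is a limit of the assay and not a number. Compound 3 also stands at a limit, > 10000 nM, so no step can be read between compound 3 and compound 4, nor between compound 1 and compound 2. The compounds shown leave open what size of step, if any, dimethylamino in place of methoxy on an aromatic carbon makes in this assay.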